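The source may hold more compounds than are shown below. What is called first, only, known or untested is meant among the compounds shown, and "the series" means these compounds.

Compound 3 `C=C(Br)C(=O)Nc1ccc(/C=C/C(=O)c2ccc(Br)cc2)cc1` gives 620 nM in a functional assay on L1210 cells (Mus musculus) for antiproliferative activity, with a stated time of 48 h; on this read-out lower numbers stand for stronger inhibition and higher numbers for weaker inhibition; compound 2 `C=C(Br)C(=O)Nc1ccc(/C=C/C(=O)c2ccc(Cl)cc2)cc1` gives 1100 nM, a gap within the scatter, while compound 1 `C=C(Br)C(=O)Nc1ccc(/C=C/C(=O)c2ccccc2)cc1` gives 5000 nM, the clearly highest number of the three. Next is compound 4 `C=C(Br)C(=O)Nc1ccc(/C=C/C(=O)c2ccc(C)cc2)cc1`, with the change (methyl in place of bromo on an aromatic carbon). Within the data shown here, no measured step swaps bromo for methyl. Bearing on it are an 8.1-fold lower number from compound 1 to compound 3 (0.91 log units; beyond the scatter) and a 4.5-fold lower number from compound 1 to compound 2 (0.66 log units; beyond the scatter), both showing that a group on this aromatic carbon lowers the number, whereas a 1.8-fold lower number from compound 2 to compound 3 (0.25 log units; within the scatter) shows little between two such groups. Methyl is assumed to act like a smaller such group, so for compound 4 the expected step is a 2.4-fold higher number from compound 3 to compound 4 (0.38 log units; beyond the scatter), a modest rise. Compound 4 is estimated at 1500 nM, range 600 nM to 4000 nM.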

Compound 4, half-maximal inhibitory concentration: 1900 nM
Compound 4: middle estimate off by 1.3-fold (0.10 log units), on the low side, within the range that was stated.
By their numbers in this assay, from the lowest: compounds 3, 2 and 4 (each within the scatter of the next, the first and the last beyond it); then compound 1.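

In this assay methyl gives a 2.6-fold lower number from compound 1 to compound 4 (0.42 log units; beyond the scatter), so lowering the number relative to hydrogen at this position is not limited to the two halogens. Methyl in place of chloro gives a 1.7-fold higher number from compound 2 to compound 4 (0.24 log units; within the scatter) and cannot be separated from chloro, whereas methyl in place of bromo gives a 3.1-fold higher number from compound 3 to compound 4 (0.49 log units; beyond the scatter) and can be told apart from bromo, although one heavy atom leaves and one enters. No evidence is available to explain these steps.

Still open, on these data alone, is whether an amine, a carboxylic acid or a longer chain at this position would also lower the number.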